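This account rests on a few compounds, and the source may have more. Where it says the series, first, only, none or still open, it means among the compounds named here.

Measured compounds:
compound 1 `COc1ccc(S(=O)(=O)N2CCc3cccc(Nc4ccc(O)cc4)c32)cc1` — 511 nM
compound 2 `COc1ccc(S(=O)(=O)N2CCc3cccc(Nc4ccc(Cl)cc4)c32)cc1` — 658 nM
compound 3 `COc1ccc(S(=O)(=O)N2CCc3cccc(Nc4ccc(F)cc4)c32)cc1` — 588 nM

In a functional assay on HT-29 cells (Homo sapiens) for antiproliferative activity (on this read-out lower numbers stand for stronger inhibition and higher numbers for weaker inhibition), compound 1 gives 511 nM, the lowest of the three numbers, but its steps to the other two, a 1.3-fold higher number from compound 1 to compound 2 (0.11 log units; within the scatter) and a 1.2-fold higher number from compound 1 to compound 3 (0.06 log units; within the scatter), both sit within the scatter, so no order among compounds 1, 2 and 3 can be read from these data. The remaining step, a 1.1-fold lower number from compound 2 to compound 3 (0.05 log units; within the scatter), is likewise within the scatter.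

The unmeasured compound 4 `COc1ccc(S(=O)(=O)N2CCc3cccc(Nc4ccc(F)c(F)c4)c32)cc1` differs from compound 1 by 3,4-difluorophenyl in place of 4-hydroxyphenyl on a nitrogen on an aromatic ring. Among the compounds with values here, the measured steps from compound 1 to compounds 2 and 3 exchanged hydroxy for a single halogen on an aromatic carbon and left the number within the scatter; the step to compound 4 again removes hydroxy and brings in fluoro, here as the 3,4-difluorophenyl group, for which no measured step exists. Since every exchange on this phenyl ring among compounds 1, 2 and 3 has stayed within the scatter, the expectation for compound 4 in this assay is a step of a 1.2-fold higher number from compound 1 to compound 4 (0.08 log units; within the scatter), that is nothing beyond the scatter. Compound 4 is expected to give 620 nM, with a range of 300 nM to 1300 nM.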

Compound 4, half-maximal inhibitory concentration: 968 nM
Beside the measured number, compound 4's estimate is 1.6-fold (0.19 log units) below it; the measured number falls inside the stated range.
By their numbers in this assay, from the lowest: compounds 1, 3, 2 and 4 (each within the scatter of the next).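

On a nitrogen on an aromatic ring, the position takes a phenyl group with two fluoro groups, and all three new steps in this assay stay within the scatter (a 1.9-fold higher number from compound 1 to compound 4 (0.28 log units; within the scatter)) and (a 1.6-fold higher number from compound 3 to compound 4 (0.22 log units; within the scatter)) and (a 1.5-fold higher number from compound 2 to compound 4 (0.17 log units; within the scatter)). Within the data shown here, the one further fluoro that compound 4 carries over compound 3 thus extends the earlier single-halogen exchanges to a doubly substituted ring, with no readable change in the number. The exchange of 4-hydroxyphenyl, with 1 hydrogen-bond donor and 1 hydrogen-bond acceptor, for 3,4-difluorophenyl, with 0 of each, likewise leaves the number within the scatter, so in these four compounds this read-out does not depend on that donor and acceptor.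

All the ring substituents shown are hydroxy, chloro or fluoro, so the response of this position to an amine, a carboxylic acid or a longer chain on the phenyl ring remains open. Nothing available bears on why the numbers fall as they do.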